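The source may report more compounds than this note shows. Statements on the series, on what has been measured and on what is new or still open speak of the compounds shown alone.

The series shares one core, seen in compound 1 `O=C(/C=C/c1ccc2c(c1)B(O)OC2)c1ccc(F)cc1`. Going by the values given here, in a functional assay on HCT-116 cells (Homo sapiens) for cytotoxicity, read by MTT assay, with a stated time of 48 h (a lower number here means a stronger inhibitor, a higher number a weaker inhibitor), compound 1 gives 2800 nM, the lowest of the three numbers so far. Compound 2 `CSc1ccc(C(=O)/C=C/c2ccc3c(c2)B(O)OC3)cc1` gives 10300 nM and compound 3 `O=C(/C=C/c1ccc2c(c1)B(O)OC2)c1ccc([N+](=O)[O-])cc1` gives 9100 nM; the steps of a 3.7-fold higher number from compound 1 to compound 2 (0.57 log units; beyond the scatter) and a 3.3-fold higher number from compound 1 to compound 3 (0.51 log units; beyond the scatter) are both modest, while a 1.1-fold lower number from compound 2 to compound 3 (0.05 log units; within the scatter). Compound 4 `O=C(/C=C/c1ccc2c(c1)B(O)OC2)c1ccccc1O` is not yet measured; it differs from compound 1 by 2-hydroxyphenyl in place of 4-fluorophenyl on a carbonyl carbon. Both measured steps away from compound 1 replaced fluoro on an aromatic carbon rather than exchanging the whole aryl, so they bear only loosely here, yet each raised the number modestly. A similar modest rise is therefore expected, a 2.0-fold higher number from compound 1 to compound 4 (0.29 log units; within the scatter). The estimate for compound 4 is 5500 nM, with a range from 2000 nM to 16000 nM.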

Compound 4, half-maximal inhibitory concentration: 77900 nM
Compound 4: the middle estimate sits 14-fold (1.15 log units) below what was measured, and the stated range ends below it.
By their numbers in this assay, from the lowest: compound 1; then compounds 3 and 2 (each within the scatter of the next); then compound 4.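

Exchanging the whole aryl on the carbonyl carbon moves the number much further than either exchange of fluoro on an aromatic carbon: a 28-fold higher number from compound 1 to compound 4 (1.44 log units; beyond the scatter) is large, whereas the steps to compound 2 and compound 3 are modest. This position therefore does not accept 2-hydroxyphenyl in place of 4-fluorophenyl with the small change seen for the earlier substituents. No measurement here accounts for the size of this step.

The compounds shown leave open whether the hydroxyl or its place on the ring carries the step. Plain phenyl, or an amine or a carboxylic acid on the aryl, would bear on that question.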